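The source may report more compounds than this note shows. Statements on the series, on what has been measured and on what is new or still open speak of the compounds shown alone.

Measured so far:
- compound 1 `Nc1cc(N)c2nc(-c3ccccc3)c(Oc3ccc(Cl)c(Cl)c3)nc2c1` — < 100000 nM
- compound 2 `COc1cc(CNc2nc3cc(N)cc(N)c3nc2-c2ccccc2)cc(OC)c1OC` — < 50200 nM

In a functional assay on DU-145 cells (Homo sapiens) for inhibition, read by sulforhodamine B assay, with a stated time of 48 h (a higher number here means that more compound is tolerated, a lower number that less compound is tolerated), compound 1 gives < 100000 nM, which is a limit of the assay and not a number. In this assay compound 2 gives < 50200 nM, again a limit rather than a number. Within the data shown here, the two compounds differ in more than one place, so no single step between them is taken; their values show only that each sits at a limit, as noted at the limit of < 100000 nM in this assay, at which 1 of the 2 values shown sits, and (the limit of < 50200 nM in this assay, at which 1 of the 2 values shown sits). Compound 1 therefore has no fixed position on a scale, only a bound in this assay.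

Compound 3 `COc1ccc(Sc2nc3cc(N)cc(N)c3nc2-c2ccccc2)cc1` is to be measured in this assay. The change from compound 1 is (4-methoxyphenyl)sulfanyl in place of 3,4-dichlorophenoxy on an aromatic carbon. With compound 1 known only as a limit, the size of the step cannot be anchored; the expectation is a step of no more than the usual scatter in either direction, with the outcome possibly again reported as a limit. The expected step is a step that the limit leaves unreadable from compound 1 to compound 3. For compound 3 the estimate in this assay is 20000 nM, with a range from 3000 nM to 100000 nM.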

Compound 3, concentration lethal to 50% of the cells: 69200 nM
Compound 3: the middle estimate sits 3.5-fold (0.54 log units) below what was measured; measured number inside the range.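

In this assay no step from compound 1 to compound 3 can be read, because compound 1 stands only at a limit of the assay and not at a number: the limit of < 100000 nM in this assay, at which 1 of the 3 values shown sits.

The compounds shown leave open how large the effect of (4-methoxyphenyl)sulfanyl in place of 3,4-dichlorophenoxy is in this assay, and in which direction it runs.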